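This account rests on a few compounds, and the source may have more. Where it says the series, first, only, none or still open, it means among the compounds named here.

Measured so far in a functional assay on NCI-H1975 cells (Homo sapiens) for inhibition, read by MTT assay, with a stated time of 72 h; on this read-out lower numbers stand for stronger inhibition and higher numbers for weaker inhibition:
- compound 1, `O=C(CSc1nc(Nc2ccccc2)c2ccccc2n1)Nc1ccc(C(F)(F)F)cc1`: 11700 nM
- compound 2, `CCc1ccc(NC(=O)CSc2nc(Nc3ccccc3)c3ccccc3n2)cc1`: 9910 nM
- compound 3, `C=CC(=O)Nc1cccc(NC(=O)CSc2nc(Nc3ccc(C(F)(F)F)cc3)c3ccccc3n2)c1`: 12900 nM

All three compounds share a thioether-linked acetamide on a substituted quinazoline bearing an anilino group, and all three give numbers that lie close together. Going by the values given here, the one change that is measured on its own is the step from compound 1 to compound 2, (ethyl in place of trifluoromethyl on an aromatic carbon), which gives a 1.2-fold lower number from compound 1 to compound 2 (0.07 log units; within the scatter). Compound 3 carries a different core from compound 1; the difference between the two cores is not broken down here, and the two values themselves sit within the usual scatter of each other.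

Compound 4, `C=CC(=O)Nc1cccc(NC(=O)CSc2nc(Nc3ccc(CC)cc3)c3ccccc3n2)c1`, is not yet measured. It differs from compound 3 in the same way that compound 2 differs from compound 1: ethyl in place of trifluoromethyl on an aromatic carbon. Because the earlier step, a 1.2-fold lower number from compound 1 to compound 2 (0.07 log units; within the scatter), stayed within the scatter, the same change on the core of compound 3 is expected to give a similarly small step, a 1.2-fold lower number from compound 3 to compound 4 (0.07 log units; within the scatter). On that basis compound 4 is estimated to give 11000 nM in this assay, with a plausible range from 5500 nM to 22000 nM.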

Compound 4, half-maximal inhibitory concentration: 8270 nM
Beside the measured number, compound 4's estimate is 1.3-fold (0.12 log units) above it; the range from low to high includes it.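

In this assay, ethyl in place of trifluoromethyl gives a 1.6-fold lower number from compound 3 to compound 4 (0.19 log units; within the scatter), and set beside the same change on the other core, the step reads much the same: the same change on two cores in this assay, a 1.2-fold lower number (0.07 log units; within the scatter) from compound 1 to compound 2 and a 1.6-fold lower number (0.19 log units; within the scatter) from compound 3 to compound 4, 1.3-fold (0.12 log units) apart, within the scatter of two such steps. Within this pair of cores, then, the change carries over as a small step on both, and the two steps cannot be told apart. It does not show that the change has any effect of its own, as each step lies within the scatter, and two cores say nothing about how the change would read on a third.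

The compounds shown leave open whether a different group at this place, such as an amine, a carboxylic acid or a longer chain in place of ethyl, would move the number beyond the scatter. They also leave open whether a nitrile or a methoxy group there would give a step that differs between the two cores.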